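This account rests on a few compounds, and the source may have more. Where it says the series, first, only, none or still open, it means among the compounds named here.

Of the compounds shown here, two with a shared core have been measured in an assay on HEK293 cells for inhibition of N-acylethanolamine-hydrolyzing acid amidase (Rattus norvegicus), read by LC-MS, with a stated time of 30 min; on this read-out higher numbers stand for weaker inhibition and lower numbers for stronger inhibition. Compound 1 `Cc1cccc(CCCCCCC(=O)N2CCCC2)c1` carries a methyl group on its benzene ring, and in this assay compound 1 gives 8300 nM. Compound 2 `Cc1ccc(CCCCCCC(=O)N2CCCC2)cc1` carries the same methyl group at a different position of that ring, and in this assay compound 2 gives 9600 nM. Compound 2 has the higher of the two numbers, but the gap to compound 1 lies within the scatter of repeated measurements, so the two cannot be told apart on these data.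

The next compound, compound 3 `O=C(CCCCCCc1ccc(Cl)cc1)N1CCCC1`, keeps the core of compound 2 and changes one group: chloro in place of methyl on an aromatic carbon. Going by the values given here, no measured pair shows what such an exchange does here, so the expectation rests only on the pattern that the two methyl compounds sit close together. A step of modest size is expected from compound 2 to compound 3, most likely toward a somewhat lower number, as a 1.4-fold lower number from compound 2 to compound 3 (0.14 log units; within the scatter), but one that may well stay within the scatter. Compound 3 is estimated at 7000 nM, with a range from 2500 nM to 20000 nM.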

Compound 3, half-maximal inhibitory concentration: 34500 nM
Compound 3: the middle estimate sits 4.9-fold (0.69 log units) below what was measured; measured number above the stated range.
By their numbers in this assay, from the lowest: compounds 1 and 2 (each within the scatter of the next); then compound 3.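

In this assay, chloro in place of methyl on an aromatic carbon, para to a large group, gives a 3.6-fold higher number from compound 2 to compound 3 (0.56 log units; beyond the scatter) and so moves toward weaker inhibition. Going by these compounds alone, compound 1 and compound 2 showed only that the methyl group can sit at either of two ring positions without a difference that can be told from scatter, whereas this step shows that the read-out does respond to which group occupies this place. The size of the step is notable since each group counts as a single heavy atom, with no ring, no hydrogen-bond donors or acceptors and no net charge, yet no measurement shown here says what lies behind the change.

Still open, from the compounds shown here alone, is whether chloro at the ring position held by the methyl group of compound 1 would also give a higher number than that methyl compound. Also open, going by these compounds, is how other groups in the place of chloro, such as fluoro, methoxy or a carboxylic acid, would compare with methyl and chloro, and whether the step would hold on a shorter chain.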